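A few compounds are considered here, and "the series" means these few. Any claim that something is new, unique, unknown or untested is made for them only; others in the source may bear on it.

In a functional assay on HT-1080 cells (Homo sapiens) for antiproliferative activity, read by MTT assay, with a stated time of 72 h (on this read-out higher numbers stand for weaker inhibition and lower numbers for stronger inhibition), compound 1 (`CCOC(=O)c1cc(-c2cc(OC)c(OC)c(OC)c2)c(-c2ccc(OC)cc2)s1`) gives 8370 nM. Compound 2 (`CCOC(=O)c1cc(-c2cc(OC)c(OC)c(OC)c2)c(-c2cccc(Br)c2)s1`) gives > 100000 nM, which is a limit and not a number. Compound 3 (`CCOC(=O)c1cc(-c2cc(OC)c(OC)c(OC)c2)c(-c2ccc(OC)c(OCc3ccccc3)c2)s1`) gives > 100000 nM, again only a limit. That places compound 3 at the limit of > 100000 nM in this assay, at which 2 of the 3 values shown sit. Compound 4 (`CCOC(=O)c1cc(-c2cc(OC)c(OC)c(OC)c2)c(-c2ccc(OC)c(O)c2)s1`) differs from compound 3 as follows: hydrogen in place of benzyl on an oxygen on an aromatic ring, that is, benzyloxy to hydroxy. The measured step that bears most directly on this change is an at least 11-fold higher number from compound 1 to compound 3 (1.07 log units; beyond the scatter), where benzyloxy stands in place of hydrogen. The step of an at least 11-fold higher number from compound 1 to compound 2 (1.07 log units; beyond the scatter), with 3-bromophenyl in place of 4-methoxyphenyl, bears less directly but is also large. Removing the benzyl reverses part of the first change, so a large move to a lower number is expected, an at least 20-fold lower number from compound 3 to compound 4 (1.30 log units; beyond the scatter). Compound 4 is estimated at 5000 nM, within an expected range of 500 nM to 50000 nM.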

Compound 4, half-maximal inhibitory concentration: 3220 nM
The estimate for compound 4 lay 1.6-fold (0.19 log units) above the measured number; the measured number falls inside the stated range.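

At the oxygen on this aromatic ring, the size of the group decides the outcome in this assay, with an at least 31-fold lower number from compound 3 to compound 4 (1.49 log units; beyond the scatter) when hydrogen replaces benzyl. Hydroxy, unlike benzyloxy, goes with stronger inhibition than the unsubstituted position, giving a 2.6-fold lower number from compound 1 to compound 4 (0.41 log units; beyond the scatter), a modest step, while the change of the whole ring gives an at least 31-fold lower number from compound 2 to compound 4 (1.49 log units; beyond the scatter) and is large. The two large steps start from a limit and not from a number: the limit of > 100000 nM in this assay, at which 2 of the 4 values shown sit.

The compounds shown leave open how an amine or an ethoxy group at this place would compare with hydroxy, and whether a carboxylic acid in place of the ester would keep this activity.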